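Methyl in Place of Methoxy: A Step from Compound 2

The source may hold more compounds than are shown below. What is called first, only, known or untested is meant among the compounds shown, and "the series" means these compounds.

Measured compounds:
compound 1 `COc1cc(C)nc2n/c(=N/C(=O)c3c(-c4ccc(Cl)cc4Cl)noc3C)sn12`: 80.4%
compound 2 `COc1cc(SC)nc(NC(=S)NC(=O)c2c(-c3ccc(Cl)cc3Cl)noc2C)n1`: 60.3%

In a functional assay on the whole organism for inhibition, with Chenopodium ficifolium as the target, with a stated time of 72 h, tested at 100 mg/L (a higher number here means more inhibition of growth at the concentration tested, a lower number less inhibition of growth), compound 2 gives 60.3%, the lower of the two numbers. Compound 1 gives 80.4%, a number higher by a difference beyond the scatter. Compound 3 `CSc1cc(C)nc(NC(=S)NC(=O)c2c(-c3ccc(Cl)cc3Cl)noc2C)n1` differs from compound 2 by methyl in place of methoxy on an aromatic carbon. Going by the values given here, no step between measured compounds covers this change, so no guidance on its size exists; a small step, within the scatter, in either direction is expected, a number 0.3 percentage points lower from compound 2 to compound 3 (within the scatter). Compound 3 is therefore estimated at 60%, in a range from 40% to 80%.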

Compound 3, percent growth inhibition at one concentration: 86.1%
Beside the measured number, compound 3's estimate is 26.1 percentage points below it; the measured number lies above the stated range.
By their numbers in this assay, from the lowest: compound 2; then compounds 1 and 3 (each within the scatter of the next).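

In this assay, the change from methoxy to methyl on this aromatic carbon gives a number 25.8 percentage points higher from compound 2 to compound 3 (beyond the scatter), so the swap is not a silent one. With the methylsulfanyl group kept, the position responds to which of these two groups it carries, something compound 1 and compound 2 alone could not show. Nothing given here accounts for the size of this step. As far as these compounds go, how an amine, an ethyl group or a chlorine would read at this position remains open, as does whether the step would hold without the methylsulfanyl group.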